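The source may report more compounds than this note shows. Statements on the series, on what has been measured and on what is new or still open speak of the compounds shown alone.

Measured so far in a functional assay (Cavia porcellus) with sulfonylurea receptors; K-ATP channels (Homo sapiens) as the target; on this read-out higher numbers stand for weaker inhibition and lower numbers for stronger inhibition:
compound 1 `CC(O)(C(=O)Nc1ccc(S(=O)(=O)c2ccc(F)cc2)cc1)C(F)(F)F` gives 8600 nM
compound 2 `CC(O)(C(=O)Nc1ccc(C#N)c(S(=O)(=O)c2ccccc2)c1)C(F)(F)F` gives 2600 nM
compound 3 `COc1cc(NC(=O)C(C)(O)C(F)(F)F)ccc1S(=O)(=O)c1ccccc1` gives 5900 nM

Compound 1 stands at the highest of the three numbers. Its gap to compound 3 lies within the usual scatter of repeated measurements, so the two cannot be told apart on these data. Its gap to compound 2 lies beyond the scatter: compound 2 gives the stronger inhibition of the pair.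

Compound 4 `COc1cccc(S(=O)(=O)c2ccc(NC(=O)C(C)(O)C(F)(F)F)cc2)c1` is not yet measured. It differs from compound 1 in one place: 3-methoxyphenyl in place of 4-fluorophenyl on a sulfonyl sulfur. Among the measured compounds shown here, no measured pair differs by this exchange alone, so there is no step on which to rest a direction, and compounds 2 and 3 offer no guide to it. The expectation is that the step of a 1.2-fold lower number from compound 1 to compound 4 (0.09 log units; within the scatter) stays within the scatter, in no particular direction. Compound 4 is accordingly expected to give about 7000 nM in this assay, with a range from 2500 nM to 20000 nM.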

Compound 4, half-maximal inhibitory concentration: 16000 nM
Beside the measured number, compound 4's estimate is 2.3-fold (0.36 log units) below it; the range from low to high includes it.
By their numbers in this assay, from the lowest: compound 2; then compounds 3, 1 and 4 (each within the scatter of the next, the first and the last beyond it).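

In this assay, among the compounds shown here, the exchange of 4-fluorophenyl for 3-methoxyphenyl on a sulfonyl sulfur gives the first readable step, a 1.9-fold higher number from compound 1 to compound 4 (0.27 log units; within the scatter), so the two compounds cannot be told apart. At this position, then, a change from a fluorine-bearing group to an oxygen-bearing group with a hydrogen-bond acceptor leaves the number within the scatter, which holds for this one exchange only. No measured property of either group bears on this step.

Going by these compounds, whether an amine or a carboxylic acid in place of the methoxy group on this ring would take the number beyond the scatter remains open. On these data alone, it is also open whether 3-methoxyphenyl would behave the same way on the cores of compound 2 and compound 3.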